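This account rests on a few compounds, and the source may have more. Where it says the series, first, only, none or still open, it means among the compounds named here.

Compound 1, `CCN1CCc2c(sc(NC(=O)Nc3ccc(Cl)cc3)c2C(=O)c2nnco2)C1`, gives > 25000 nM in a functional assay (strain AB) with Danio rerio as the target, read by microscopy, with a stated time of 1 h; a higher number here means that more compound is needed for the effect, a lower number that less compound is needed.
Compound 2, `CC(C)(C)OC(=O)CCCCCN1CCc2c(sc(NC(=O)Nc3ccc(Cl)cc3)c2C(N)=O)C1`, gives 620 nM in this assay.
Compound 3, `CC(C)(C)OC(=O)CCCC[N+]1(C)CCc2c(sc(NC(=O)Nc3ccc(Cl)cc3)c2C(N)=O)C1`, gives 140 nM in this assay.

All three compounds share one core and differ only in the group carried on the ring nitrogen. Compound 3 stands lowest of the two numbers that were actually measured, meaning it needs the least compound for the effect. The nearest value, that of compound 2, is a larger number, and the gap lies beyond the usual scatter. For compound 1 the result is not a number but a limit of the assay, as the limit of > 25000 nM in this assay, at which 1 of the 3 values shown sits, states, so it cannot be placed against the other two.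

The next compound, compound 4, is `C[N+]1(CC2CC2)CCc2c(sc(NC(=O)Nc3ccc(Cl)cc3)c2C(N)=O)C1`. It differs from compound 3 in one place: cyclopropyl in place of 3-(tert-butoxycarbonyl)propyl on a saturated chain carbon bound to an amine nitrogen in a ring. Among the compounds measured so far no pair differs in this way, so no measured step shows how such a change plays out. Compound 4 is therefore expected to give 400 nM in this assay, with a range from 80 nM to 2500 nM, which means an expected step of a 2.9-fold higher number from compound 3 to compound 4 (0.46 log units; beyond the scatter).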

Compound 4, half-maximal effective concentration: 360 nM
Estimate against measurement, compound 4: 1.1-fold (0.05 log units) above; measured number inside the range.
By their numbers in this assay, from the lowest: compound 3; then compounds 4 and 2 (each within the scatter of the next). At a limit, above all of these: compound 1.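

In this assay, putting cyclopropyl in place of 3-(tert-butoxycarbonyl)propyl on a saturated chain carbon bound to an amine nitrogen in a ring gives a 2.6-fold higher number from compound 3 to compound 4 (0.41 log units; beyond the scatter). Among the compounds shown here, this is the first step measured at this position, and it shows that the group there can shrink from 10 heavy atoms to 3, and lose both its oxygens and its double bond, at a modest cost, with compound 4 still giving 360 nM. Nothing measured here bears on why the number moves this way, and a single step cannot supply a reason.

The compounds shown leave open which part of the swap matters more, the loss of the long chain with its two oxygens or the arrival of the three-membered ring, as both happen in this one step. A plain butyl chain in the same place, or a chain of similar length ending in a carboxylic acid or an amine, would help to separate these two parts.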